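The source may hold more compounds than are shown below. What is called first, only, known or untested is meant among the compounds shown, and "the series" means these compounds.

The series shares one core. Compound 1 `O=C(Nc1ccc2nc(NC(=O)C3CCCCC3)sc2c1)c1ccccc1C(F)(F)F` carries a 2-(trifluoromethyl)phenyl on the carbonyl carbon, compound 2 `N#Cc1ccc(C(=O)Nc2ccc3nc(NC(=O)C4CCCCC4)sc3c2)cc1` a 4-cyanophenyl in the same place. In a functional assay on WI-38 VA13 cells (Homo sapiens) for cytotoxicity (on this read-out higher numbers stand for an effect only at larger amounts of compound and lower numbers for an effect already at smaller amounts), compound 1 gives 0.024 ug/mL, and compound 2 gives 3.3 ug/mL. Among the compounds with values here, compound 2 therefore stands highest of the two numbers measured so far, its only neighbour being compound 1 at a far lower number; the single measured step, a 140-fold higher number from compound 1 to compound 2 (2.14 log units; beyond the scatter), shows that the group on this carbonyl carbon moves the read-out strongly.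

Compound 3 `O=C(Nc1ccc2nc(NC(=O)C3CCCCC3)sc2c1)c1cccnc1Cl` differs from compound 2 in that same place: 2-chloropyridin-3-yl in place of 4-cyanophenyl on a carbonyl carbon. Within the data shown here, no measured step exchanges a 4-cyanophenyl for a 2-chloropyridin-3-yl, so only the step from compound 1 to compound 2 bears on it, and only indirectly: it says the swing in this assay can be large, not which way this particular exchange goes. The expectation leans toward a lower number than compound 2, with a wide range. The expected step is an 8.3-fold lower number from compound 2 to compound 3 (0.92 log units; beyond the scatter). Compound 3 is estimated at 0.4 ug/mL, with a range from 0.03 ug/mL to 5 ug/mL.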

Compound 3, half-maximal effective concentration: 0.075 ug/mL
Compound 3: the middle estimate sits 5.3-fold (0.73 log units) above what was measured; measured number inside the range.
By their numbers in this assay, from the lowest: compound 1; then compound 3; then compound 2.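

In this assay the exchange gives a 44-fold lower number from compound 2 to compound 3 (1.64 log units; beyond the scatter), so a second group besides 2-(trifluoromethyl)phenyl now lies far below 4-cyanophenyl on this carbonyl carbon, and the large swing is no longer tied to a single pair of groups. The two low groups stand much closer together, with a 3.1-fold higher number from compound 1 to compound 3 (0.49 log units; beyond the scatter), yet that step is still beyond the scatter, so this position also separates 2-chloropyridin-3-yl from 2-(trifluoromethyl)phenyl, which keeps the lowest number of the three. No measurement at hand gives a reason for these differences.

The exchange from compound 2 to compound 3 alters the ring atoms and the substituent together, so the three compounds cannot divide the step among the loss of the nitrile, the arrival of the chlorine and the ring nitrogen; an unsubstituted phenyl and a pyridin-3-yl without chlorine would bear directly on that split. Also open, going by these compounds, is whether the same order of groups holds when an amine or a longer chain stands on this carbonyl carbon's ring, or when the other amide of the shared core changes.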